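A Urea Side Chain Exchanged for a Vinyl Group

A few compounds are considered here, and "the series" means these few. Any claim that something is new, unique, unknown or untested is made for them only; others in the source may bear on it.

Compound 1 `O=C(NCCCCl)Nc1ccc(I)cc1` is tested in a functional assay on HT-29 cells (Homo sapiens) for antiproliferative activity, with a stated time of 48 h (a higher number here means a weaker inhibitor, a lower number a stronger inhibitor), where compound 1 gives 90000 nM. Of the two numbers at hand it is the highest. Its nearest neighbour is compound 2 `CC(C)(C)c1ccc(NC(=O)NCCCCl)cc1`, which in this assay gives 28000 nM; the step of a 3.2-fold lower number from compound 1 to compound 2 (0.51 log units; beyond the scatter) arises from tert-butyl in place of iodo on an aromatic carbon. Compound 3 `CCNC(=O)NCc1ccc(C(C)(C)C)cc1` gives no number but a limit, > 100000 nM. That value is the one sitting at the limit of > 100000 nM in this assay, at which 1 of the 3 values shown sits.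

Compound 4 `C=CC(=O)Nc1ccc(I)cc1` is not yet measured. It differs from compound 1 by vinyl in place of (3-chloropropyl)amino on a carbonyl carbon: the (3-chloropropyl)amino group leaves and a vinyl group enters on a carbonyl carbon whose other neighbour is an amide-type nitrogen. For the measured compounds named here, no measured step touches this position; the only step measured, between the aromatic substituents of the first two compounds, is modest. There is thus nothing to call for a change beyond the scatter in this assay, in either direction. Compound 4 is therefore expected to give about 70000 nM, within 15000 nM to 200000 nM. This estimate means a step of a 1.3-fold lower number from compound 1 to compound 4 (0.11 log units; within the scatter) that is expected to stay within the scatter, with a fair chance that only a limit is reported.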

Compound 4, half-maximal inhibitory concentration: 15000 nM
For compound 4 the middle estimate is 4.7-fold (0.67 log units) above the measured one, and the stated range covers the measured number.
By their numbers in this assay, from the lowest: compounds 4 and 2 (each within the scatter of the next); then compound 1. At a limit, above all of these: compound 3.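

The carbonyl carbon whose other neighbour is an amide-type nitrogen proves to be a place where a change registers in this assay, and the exchange of (3-chloropropyl)amino for vinyl gives a 6.0-fold lower number from compound 1 to compound 4 (0.78 log units; beyond the scatter). For the compounds shown here, this is the first measured change at this place, and it shows that the (3-chloropropyl)amino group, with its chlorine and its hydrogen-bond donor, is not required for the activity of the core of compound 1, as the smaller vinyl group, with a double bond outside aromatic rings, gives the lower number. Nothing measured in the compounds shown bears on why the number falls with this change.

The compounds shown leave open whether the double bond of the vinyl group matters or whether the departure of the chain is enough, a question that an ethyl group or a plain amine on the same carbonyl carbon would address. They also leave open whether the same exchange holds with tert-butyl on the aromatic carbon in place of iodo, the substituent carried by compound 2.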